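The compounds below may be only part of what the source reports. "The series", "measured", "known", "first", "only" and "open" are said of these compounds alone.

For the measured compounds named here, the three compounds measured so far share one core and differ only in the group carried on the saturated ring carbon of the five-membered non-aromatic ring with one nitrogen and one oxygen. Compound 1 `O=C1OC(c2ccccc2)CN1c1ccc2c(c1)CCNCC2` gives 16 nM in an assay on CHO-K1 cells for displacement of a labelled ligand from 5-hydroxytryptamine receptor 6 (Homo sapiens), read by scintillation counting, with a stated time of 3 h; on this read-out lower numbers stand for stronger inhibition and higher numbers for weaker inhibition. Compound 2 `O=C1OC(c2ccccc2F)CN1c1ccc2c(c1)CCNCC2` gives 15 nM in this assay, and a 1.1-fold lower number from compound 1 to compound 2 (0.03 log units; within the scatter). Compound 3 `COc1ccccc1C1CN(c2ccc3c(c2)CCNCC3)C(=O)O1` gives 87 nM in this assay, the highest of the three numbers: a 5.4-fold higher number from compound 1 to compound 3 (0.74 log units; beyond the scatter), and a 5.8-fold higher number from compound 2 to compound 3 (0.76 log units; beyond the scatter).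

Compound 4 `O=C1OC(c2cccc(Cl)c2)CN1c1ccc2c(c1)CCNCC2` has not yet been measured. Relative to compound 3 the change is 3-chlorophenyl in place of 2-methoxyphenyl on a saturated ring carbon. Going by the values given here, no measured step exchanges hydrogen or fluoro for chloro, so the steps that bear on this change are those that introduced the methoxy: a 5.4-fold higher number from compound 1 to compound 3 (0.74 log units; beyond the scatter) and a 5.8-fold higher number from compound 2 to compound 3 (0.76 log units; beyond the scatter) both set compound 3 well above the analogues without it, while compound 2 shows that fluoro on the phenyl stays within the scatter of compound 1. Removing the methoxy is therefore expected to bring compound 4 back toward those lower numbers. The expected step in this assay is a 4.0-fold lower number from compound 3 to compound 4 (0.60 log units; beyond the scatter). The estimate for compound 4 in this assay is 22 nM, with a range from 8 nM to 60 nM.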

Compound 4, inhibition constant: 10 nM
Beside the measured number, compound 4's estimate is 2.2-fold (0.34 log units) above it, within the range that was stated.
By their numbers in this assay, from the lowest: compounds 4, 2 and 1 (each within the scatter of the next); then compound 3.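

In this assay, the step from 2-methoxyphenyl to 3-chlorophenyl on this saturated ring carbon next to the ring oxygen is an 8.7-fold lower number from compound 3 to compound 4 (0.94 log units; beyond the scatter), larger than either step that set compound 3 apart from the compounds without methoxy. A chloro on the phenyl also leaves the number within the scatter, with a 1.6-fold lower number from compound 1 to compound 4 (0.20 log units; within the scatter) and a 1.5-fold lower number from compound 2 to compound 4 (0.18 log units; within the scatter), so compound 1, compound 2 and compound 4 form one group, and among the four compounds only compound 3, with its 2-methoxyphenyl, stands apart from it. No measurement shown accounts for this difference between 2-methoxyphenyl and the other groups at this position.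

The step from compound 3 to compound 4 changes both the substituent and where it sits on the phenyl, so the compounds shown leave open how much of the gap belongs to the exchange of methoxy for chloro and how much to the different place on the ring. They also leave open whether a carboxylic acid or an amine on the phenyl would stay with compound 1, compound 2 and compound 4 or move toward compound 3.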